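Thiazole aryl variation in a benzofuran acetic acid series

A few compounds are considered here, and "the series" means these few. Any claim that something is new, unique, unknown or untested is made for them only; others in the source may bear on it.

Measured compounds:
compound 1 `Cc1nc(-c2cccs2)sc1COc1ccc2c(c1)OCC2CC(=O)O` — "not determined" (no result reported)
compound 2 `Cc1nc(-c2cccc3ccccc23)sc1COc1ccc2c(c1)OCC2CC(=O)O` — "not determined" (no result reported)
compound 3 `Cc1nc(-c2cccc(F)c2)sc1COc1ccc2c(c1)OCC2CC(=O)O` — 64.8 nM

In a functional assay on CHO cells for agonist activity at Free fatty acid receptor 1 (Homo sapiens), read by FLIPR and calcium flux (a lower number here means that less compound is needed, a higher number that more compound is needed for the effect), compound 3 gives 64.8 nM and is the only entry in the series with a number; compound 1 and compound 2 have no result reported, so compound 3 is the sole reference point. Compound 4 `Cc1nc(-c2ccc(C(F)(F)F)cc2)sc1COc1ccc2c(c1)OCC2CC(=O)O` carries 4-(trifluoromethyl)phenyl in place of 3-fluorophenyl on an aromatic carbon. Among the measured compounds shown here, no pair of measured compounds differs in this one place, so the size of the step has no precedent. Against that background, the step from compound 3 to compound 4 in this assay is expected to stay within the usual scatter, a 1.3-fold lower number from compound 3 to compound 4 (0.11 log units; within the scatter). For compound 4 the estimated value in this assay is 50 nM, with a range from 15 nM to 160 nM.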

Compound 4, half-maximal effective concentration: 96.7 nM
Compound 4: middle estimate off by 1.9-fold (0.29 log units), on the low side; low and high end bracket the measured number.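

In this assay, 4-(trifluoromethyl)phenyl in place of 3-fluorophenyl gives a 1.5-fold higher number from compound 3 to compound 4 (0.17 log units; within the scatter). Among the compounds shown here, this is the first readable step at this aromatic carbon: a group of 10 heavy atoms and one of 7 leave compound 3 and compound 4 within the scatter of each other. Nothing measured here bears on why. As far as these compounds go, both the substituent and its ring position differ in this pair, so their separate contributions stay open. Also open, from the compounds shown here alone, is how a phenyl ring carrying an amine or a carboxylic acid at this place would read in this assay.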